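Removing a Fluorine from a Cytotoxicity-Clean Series

The source may hold more compounds than are shown below. What is called first, only, known or untested is meant among the compounds shown, and "the series" means these compounds.

Of the compounds shown here, three have been measured so far.
- In an ADME assay on MT2 cells (Homo sapiens) for cytotoxicity, read by MTT assay (on this read-out higher numbers stand for lower toxicity in this test and lower numbers for higher toxicity in this test), compound 1 `O=c1ccn(CCOc2ccccc2Oc2cccc3cc(Cl)ccc23)c(=O)[nH]1` gives > 100000 nM, which is a limit of the assay and not a number.
- In this assay compound 2 `N#Cc1ccc2c(Oc3ccccc3OCCn3ccc(=O)[nH]c3=O)cc(F)cc2c1` gives > 100000 nM, again a limit.
- In this assay compound 3 `N#Cc1ccc2c(Oc3ccc(F)cc3OCCn3ccc(=O)[nH]c3=O)cccc2c1` gives > 100000 nM, also a limit.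

Compound 3 therefore stands at the limit of > 100000 nM in this assay, at which 3 of the 3 values shown sit, with no number to place it above or below its two companions. The next compound to be measured is compound 4 `N#Cc1ccc2c(Oc3ccccc3OCCn3ccc(=O)[nH]c3=O)cccc2c1`, which differs from compound 3 by hydrogen in place of fluoro on an aromatic carbon. Going by the values given here, no step between two measured compounds exists here, so the size of this change can only be guessed; since every value shown sits at the same limit, the expectation is for no step beyond the scatter, in either direction. For compound 4 the estimate in this assay is 100000 nM, between 50000 nM and 200000 nM, an expected step of a number no higher from compound 3 to compound 4 (the limit leaves the size open), most likely reported again only as a limit.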

Compound 4, half-maximal cytotoxic concentration: > 100000 nM
Compound 4: only a limit was reported; the forecaster's own chance of this, stated with the estimate: 85%; the middle value sits exactly at the limit.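

In this assay compound 4 gives > 100000 nM (a limit and not a number). No step from compound 1, compound 2 or compound 3 to compound 4 can be read: the limit of > 100000 nM in this assay, at which 4 of the 4 values shown sit.

The compounds shown leave open how far any of them lies past this limit, and whether fluoro, chloro or cyano changes that at all.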